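Acidic amide tails on the shared core

The source may hold more compounds than are shown below. What is called first, only, known or untested is meant among the compounds shown, and "the series" means these compounds.

Within the data shown here, compound 1 `CCn1c(C(=O)NCCO)ccc1C(CC)(CC)c1ccc(OCS(=O)(=O)c2ccccc2)c(C)c1` gives 17700 nM in a functional assay on PC-3 cells (Homo sapiens) for antiproliferative activity, read by MTT assay, with a stated time of 24 h (a higher number here means a weaker inhibitor, a lower number a stronger inhibitor), the highest of the three numbers measured so far. Compound 2 `CCn1c(C(=O)N[C@H](CO)C(C)C)ccc1C(CC)(CC)c1ccc(OCS(=O)(=O)c2ccccc2)c(C)c1` gives 7300 nM and compound 3 `CCn1c(C(=O)NCCC(=O)O)ccc1C(CC)(CC)c1ccc(OCS(=O)(=O)c2ccccc2)c(C)c1` gives 14400 nM. The step of a 2.4-fold lower number from compound 1 to compound 2 (0.38 log units; beyond the scatter) is the only one beyond the scatter; a 1.2-fold lower number from compound 1 to compound 3 (0.09 log units; within the scatter) and a 2.0-fold higher number from compound 2 to compound 3 (0.30 log units; within the scatter) both stay within it.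

Compound 4 `CCn1c(C(=O)N[C@@H](CCC(=O)O)C(=O)O)ccc1C(CC)(CC)c1ccc(OCS(=O)(=O)c2ccccc2)c(C)c1` differs from compound 1 by 1,3-dicarboxypropyl in place of 2-hydroxyethyl on an amide-type nitrogen. Among the measured compounds shown here, two measured steps bear on this change. The step of a 1.2-fold lower number from compound 1 to compound 3 (0.09 log units; within the scatter) covers the exchange of hydroxy for carboxy on the chain and shows no movement. The step of a 2.4-fold lower number from compound 1 to compound 2 (0.38 log units; beyond the scatter) covers branching on the saturated chain carbon bound to the amide-type nitrogen and shows a modest gain. For the measured compounds named here, neither step gives grounds for a large movement, and no measured compound carries two carboxy groups.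

Compound 4 is therefore expected to land close to compound 1, with a step of a 1.3-fold lower number from compound 1 to compound 4 (0.10 log units; within the scatter) that is at most modest. The estimate for compound 4 is 14000 nM, expected to fall between 6000 nM and 32000 nM.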

Compound 4, half-maximal inhibitory concentration: > 50000 nM
Compound 4: only a limit was reported; the forecaster's own chance of this, stated with the estimate: 10%; middle value at least 3.5-fold (0.55 log units) from the limit.
By their numbers in this assay, from the lowest: compounds 2, 3 and 1 (each within the scatter of the next, the first and the last beyond it). At a limit, above all of these: compound 4.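

Compound 4 is reported only as a limit in this assay: the limit of > 50000 nM in this assay, at which 1 of the 4 values shown sits.

At this amide-type nitrogen, 1,3-dicarboxypropyl is the only tail shown to separate beyond the scatter from 2-carboxyethyl, with the step of an at least 3.4-fold higher number from compound 3 to compound 4 (0.54 log units; beyond the scatter), and it also separates from 2-hydroxyethyl, with the step of an at least 2.8-fold higher number from compound 1 to compound 4 (0.45 log units; beyond the scatter), whereas the exchange of hydroxy for carboxy alone gave the step of a 1.2-fold lower number from compound 1 to compound 3 (0.09 log units; within the scatter). The step of an at least 6.8-fold higher number from compound 2 to compound 4 (0.83 log units; beyond the scatter) shows that the gain seen with the branched tail of compound 2 does not carry over to this branched, dicarboxylic tail.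

Going by these compounds, how far compound 4 lies past its limit stays unknown, as does whether the change follows the branch or the second carboxy group. A tail with an amine or a methyl ester in place of one carboxylic acid would separate these two.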